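This account rests on a few compounds, and the source may have more. Where it says the series, first, only, none or still open, it means among the compounds named here.

Among the compounds with values here, in an ADME assay on MT4 cells (Homo sapiens) for cytotoxicity, read by MTT assay, with a stated time of 5 days (a lower number here means that less compound is tolerated, a higher number that more compound is tolerated), compound 3 (`Cc1cc(/C=C/C#N)cc(C)c1Oc1cc(Nc2ccc(C#N)cc2)nc(NC2CC2)c1`) gives 24800 nM, the highest of the three numbers so far and beyond the scatter from both others. Compound 1 (`COCCNc1cc(Oc2c(C)cc(/C=C/C#N)cc2C)nc(Nc2ccc(C#N)cc2)n1`) gives 3190 nM and compound 2 (`Cc1cc(/C=C/C#N)cc(C)c1Oc1cc(NCCN(C)C)nc(Nc2ccc(C#N)cc2)n1`) gives 3040 nM. Compound 4 (`Cc1cc(/C=C/C#N)cc(C)c1Oc1cc(NCCN(C)C)nc(Nc2ccc(C#N)cc2)c1`) has not yet been measured, and the change leading to it is 2-(dimethylamino)ethyl in place of cyclopropyl on a nitrogen on an aromatic ring. Within the data shown here, the only measured step, a 1.0-fold lower number from compound 1 to compound 2 (0.02 log units; within the scatter), stays within the scatter and does not involve cyclopropyl, so no measured step shows this exact change. Still, compound 2 carries 2-(dimethylamino)ethyl on such a nitrogen and gives 3040 nM, so a lower number is expected. The estimated step is a 5.0-fold lower number from compound 3 to compound 4 (0.70 log units; beyond the scatter). The estimate for compound 4 is 5000 nM, with an expected range from 1800 nM to 15000 nM.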

Compound 4, half-maximal cytotoxic concentration: 4270 nM
The estimate for compound 4 lay 1.2-fold (0.07 log units) above the measured number; the measured number falls inside the stated range.
By their numbers in this assay, from the lowest: compounds 2, 1 and 4 (each within the scatter of the next); then compound 3.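

Within the data shown here, replacing cyclopropyl with 2-(dimethylamino)ethyl on this nitrogen gives the first change in this assay that lies beyond the scatter, a 5.8-fold lower number from compound 3 to compound 4 (0.76 log units; beyond the scatter), so less compound is tolerated with the chain in place. The earlier step, a 1.0-fold lower number from compound 1 to compound 2 (0.02 log units; within the scatter), altered only the end of a chain and stayed within the scatter. Nothing shown here explains this difference.

On these data alone, it remains open whether losing the ring or gaining the dimethylamino end drives the step. A plain ethyl group or a longer chain such as 3-(dimethylamino)propyl on this nitrogen would help separate the two.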